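A few compounds are considered here, and "the series" means these few. Any claim that something is new, unique, unknown or untested is made for them only; others in the source may bear on it.

Measured in a functional assay on HL-60 cells (Homo sapiens) for antiproliferative activity, read by MTT assay, with a stated time of 72 h; a higher number here means a weaker inhibitor, a lower number a stronger inhibitor:
- compound 1 `COc1ccc(-c2ncnn2-c2cc(OC)c(OC)c(OC)c2)cc1`: 120 nM
- compound 2 `CCOc1ccc(-c2ncnn2-c2cc(OC)c(OC)c(OC)c2)cc1`: 20 nM

Of these two numbers, compound 1 holds the higher, which makes it the weaker inhibitor of the pair. Still to be measured is compound 3 `COc1cc(-n2ncnc2-c2cccc(F)c2)cc(OC)c1OC`, which keeps the core of compound 1 but carries 3-fluorophenyl in place of 4-methoxyphenyl on an aromatic carbon.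

Going by the values given here, only one measured step bears on this change: a 6.0-fold lower number from compound 1 to compound 2 (0.78 log units; beyond the scatter). There, methyl takes the place of hydrogen on a saturated chain carbon bound to an oxygen on an aromatic ring. This modest edit to the group that compound 3 gives up moved the number beyond the scatter, so that group is not a silent part of the structure. Among the compounds with values here, no measured compound lacks the oxygen or carries fluorine, so the direction is a judgement and not a finding. A step of similar size or somewhat larger is expected in this assay, towards a higher number. The estimated step is a 5.0-fold higher number from compound 1 to compound 3 (0.70 log units; beyond the scatter). For compound 3 the expected value is 600 nM, with an estimated range of 120 nM to 3000 nM.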

Compound 3, half-maximal inhibitory concentration: > 10000 nM
Compound 3 ended at the assay's limit; the forecaster's own chance of this, stated with the estimate: 10%; middle value at least 16-fold (1.22 log units) from the limit.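

In this assay, the earlier step, a 6.0-fold lower number from compound 1 to compound 2 (0.78 log units; beyond the scatter), showed only that the chain on the oxygen of 4-methoxyphenyl affects the number. The new step, an at least 83-fold higher number from compound 1 to compound 3 (1.92 log units; beyond the scatter), goes much further: this aromatic carbon of the five-membered ring does not tolerate every phenyl group, and replacing 4-methoxyphenyl with 3-fluorophenyl takes the compound from clearly active to the end of the measurable range. The swap alters more than one feature at once, since 4-methoxyphenyl has a hydrogen-bond acceptor that 3-fluorophenyl lacks, and the two groups differ in both the substituent and its number in the name. For compound 3, the reading of > 10000 nM is a limit of the assay and not a number: the limit of > 10000 nM in this assay, at which 1 of the 3 values shown sits.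

The compounds shown leave open which of these differences matters, and 4-fluorophenyl or 3-methoxyphenyl on the same carbon would help to separate them. Also open, going by these compounds, is whether a longer chain on the oxygen, such as propoxy, would continue the trend seen with ethoxy in compound 2 or reverse it.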